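This account rests on a few compounds, and the source may have more. Where it says the series, first, only, none or still open, it means among the compounds named here.

Measured compounds:
compound 1, `CCOC(=O)C1=C(C)N/C(=C/c2cc(C)n(-c3ccc(CN(C)C)cc3)c2C)C1=O`: 8.3
compound 2, `CCOC(=O)C1=C(C)N/C(=C/c2cc(C)n(-c3cccc(O)c3)c2C)C1=O`: "not determined" (no result reported)
compound 3, `CCOC(=O)C1=C(C)N/C(=C/c2cc(C)n(-c3ccc([S+](C)[O-])cc3)c2C)C1=O`: "not determined" (no result reported)

In a physicochemical assay for lipophilicity, read by HPLC, at pH 7.4 (a higher number here means a more lipophilic compound, a lower number a more polar compound), compound 1 gives 8.3. For compound 3 the result is "not determined" (no result reported), so no single number describes where it stands in this assay, and compound 2 is a further entry without a number, its result being "not determined" (no result reported). Among the compounds with values here, compound 1 therefore supplies the only measured value in the set.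

Compound 4, `CCOC(=O)C1=C(C)N/C(=C/c2cc(C)n(-c3cccnc3)c2C)C1=O`, differs from compound 3 in one place: a group of 6 heavy atoms (5 carbon, 1 nitrogen; one six-membered aromatic ring with 1 hetero atom) in place of a group of 9 heavy atoms (7 carbon, 1 oxygen, 1 sulfur; one six-membered aromatic ring of carbon only), on an aromatic nitrogen. Within the data shown here, since no pair of measured compounds differs in one place, no step in this assay is known, and neither the direction nor the size of the change from compound 3 to compound 4 can be read from the data. Any expectation has to lean on the one number available, and it should be held loosely, with a range wide enough to reflect that.

Against that background compound 4 is estimated at 7.5 in this assay, with a range from 6 to 9, because compound 1 gives 8.3 and nothing else in the set offers a firmer anchor.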

Compound 4, distribution coefficient: 2.1
Compound 4: the middle estimate sits 5.40 log units above what was measured; the measured number lies below the stated range.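

In this assay, within the data shown here, pyridin-3-yl in place of 4-((dimethylamino)methyl)phenyl on the aromatic nitrogen gives a number 6.20 log units lower from compound 1 to compound 4 (beyond the scatter) and thereby supplies the first readable step in the set, one that lies beyond the scatter. It shows that, with the rest of the structure held constant, the group at this one place, on the nitrogen of the five-membered aromatic ring, can go with a large shift in the reading. Compound 2 and compound 3 carry no number, so the steps that touch them cannot be read, and nothing at hand accounts for the size of the step from compound 1.

This single step changes the ring and removes the dimethylaminomethyl side chain together, so the compounds shown do not tell how much of the shift goes with either part. Going by these compounds, a plain phenyl group on the same nitrogen, or a pyridin-4-yl group there, would be the kind of neighbour that could begin to separate the two, and how either reads remains open.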